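From oxolan-3-yl to oxolan-2-yl

The source may report more compounds than this note shows. Statements on the series, on what has been measured and on what is new or still open speak of the compounds shown alone.

Measured in a physicochemical assay for lipophilicity, read by HPLC, measured as octanol-water partition, at pH 7.4; a lower number here means a more polar compound, a higher number a more lipophilic compound:
compound 1 `NC(=O)[C@@H](CCC(F)(F)F)N(CC1CCCC1)S(=O)(=O)c1ccc(Cl)cc1`: 5.15
compound 2 `NC(=O)[C@@H](CCC(F)(F)F)N(C[C@@H]1CCOC1)S(=O)(=O)c1ccc(Cl)cc1`: 2.8

In this assay, compound 2 holds the lower of the two numbers, at 2.8. Compound 3 `NC(=O)[C@@H](CCC(F)(F)F)N(C[C@@H]1CCCO1)S(=O)(=O)c1ccc(Cl)cc1` has the same atoms joined differently: oxolan-2-yl in place of oxolan-3-yl on a saturated chain carbon bound to a sulfonamide nitrogen. In words, oxolan-2-yl stands in place of oxolan-3-yl on a saturated chain carbon bound to a sulfonamide nitrogen.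

For the measured compounds named here, only one measured step bears on this, and only indirectly: a number 2.35 log units lower from compound 1 to compound 2 (beyond the scatter). That large step, beyond the scatter, came with oxolan-3-yl in place of cyclopentyl, whereas the groups exchanged here count the same. Going by the values given here, no measured step isolates such a change, so no shift beyond the scatter is expected in this assay. The estimate is a step of a number 0.20 log units higher from compound 2 to compound 3 (within the scatter). For compound 3 the estimated value is 3, with an expected range from 2.6 to 3.4.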

Compound 3, distribution coefficient: 3.5
Estimate against measurement, compound 3: 0.50 log units below, outside the stated range (above it).
By their numbers in this assay, from the lowest: compound 2; then compound 3; then compound 1.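

In this assay, oxolan-2-yl in place of oxolan-3-yl gives a number 0.70 log units higher from compound 2 to compound 3 (beyond the scatter), so on a saturated chain carbon bound to a sulfonamide nitrogen the read-out depends on how the same atoms are joined, not only on which atoms are present. Cyclopentyl replaced by oxolan-2-yl gives a number 1.65 log units lower from compound 1 to compound 3 (beyond the scatter), still a large step, so the size of the change away from cyclopentyl varies with the ring that enters. Nothing available explains the gap between the two oxolanyl groups.

The compounds shown leave open whether a similar gap appears with other groups at this place, such as oxan-4-yl or an open methoxyethyl chain. They also leave open how each oxolanyl group reads with its defined stereocentre reversed.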